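The compounds below may be only part of what the source reports. "The series", "measured", "known", "first", "only" and "open" are said of these compounds alone.

Measured compounds:
compound 1 `CC(C)(C)c1ccc(NC(=O)c2ccc(-c3ccccn3)cc2)cc1`: 31 nM
compound 2 `Cc1ccc(NC(=O)c2ccc(-c3ccccn3)cc2)cc1`: 2300 nM
compound 3 `O=C(Nc1ccc(C(F)(F)F)cc1)c1ccc(-c2ccccn2)cc1`: 7900 nM

All three share one core and differ only in the group on the outer aromatic carbon. In a functional assay on Dorsal root ganglion for antagonist activity at transient receptor potential cation channel subfamily V member 1 (Rattus norvegicus) (a higher number here means a weaker inhibitor, a lower number a stronger inhibitor), compound 1 gives 31 nM, compound 2 gives 2300 nM and compound 3 gives 7900 nM. Compound 3 therefore has the highest number of the three. The smaller of its two gaps is a 3.4-fold higher number from compound 2 to compound 3 (0.54 log units; beyond the scatter); the larger is a 250-fold higher number from compound 1 to compound 3 (2.41 log units; beyond the scatter).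

Compound 4 `CC(C)c1ccc(NC(=O)c2ccc(-c3ccccn3)cc2)cc1` has not been measured. It differs from compound 3 in one place: isopropyl in place of trifluoromethyl on an aromatic carbon. Among the measured compounds shown here, two measured steps bear on this change. Exchanging tert-butyl for methyl gave a 74-fold higher number from compound 1 to compound 2 (1.87 log units; beyond the scatter), and exchanging tert-butyl for trifluoromethyl gave a 250-fold higher number from compound 1 to compound 3 (2.41 log units; beyond the scatter); both show that tert-butyl at this place goes with a much lower number than either of the other groups tried. Isopropyl itself has not been tested here, so the picture rests on three compounds only. A large step downward from compound 3 is expected, though not necessarily all the way to the number of compound 1. Compound 4 is estimated at 200 nM, with a range from 50 nM to 1000 nM. The expected step is a 40-fold lower number from compound 3 to compound 4 (1.60 log units; beyond the scatter).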

Compound 4, half-maximal inhibitory concentration: 38 nM
Beside the measured number, compound 4's estimate is 5.3-fold (0.72 log units) above it; the measured number lies below the stated range.
By their numbers in this assay, from the lowest: compounds 1 and 4 (each within the scatter of the next); then compound 2; then compound 3.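

Isopropyl in place of trifluoromethyl gives a 210-fold lower number from compound 3 to compound 4 (2.32 log units; beyond the scatter) in this assay and isopropyl in place of methyl gives a 61-fold lower number from compound 2 to compound 4 (1.78 log units; beyond the scatter) in the same test, so tert-butyl is not the only group at this place that goes with a low number. Taking one methyl off tert-butyl gives a 1.2-fold higher number from compound 1 to compound 4 (0.09 log units; within the scatter) and leaves compound 1 and compound 4 indistinguishable, which means that the large gaps seen so far separate these two groups from methyl and trifluoromethyl, and not tert-butyl from everything else. Size counted in heavy atoms does not sort the four groups, since trifluoromethyl brings more heavy atoms than isopropyl, yet compound 3 has the highest number of the set and so goes against any simple rule that more atoms give a lower number.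

Nothing shown here explains why these groups differ so sharply. As far as these compounds go, it also remains open whether ethyl, cyclopropyl or a longer chain such as butyl at this place would sit with compound 1 and compound 4 or with compound 2, and whether an amine or a methoxy group would fit either pattern.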